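Cutting the Octyl Chain Back to a Trifluoromethyl End

The compounds below may be only part of what the source reports. "The series", "measured", "known", "first", "only" and "open" are said of these compounds alone.

Compound 1 `CCCCNc1ccc(C(=O)O)cc1S(=O)(=O)N(C)C` gives 15.6% in an assay on HEK293 cells for inhibition of solute carrier family 12 member 2 (Homo sapiens), read by fluorescence, with a stated time of 30 min, tested at 100 uM; on this read-out higher numbers stand for a stronger effect at the one concentration tested and lower numbers for a weaker effect.
Compound 2 `CCCCCCCCNc1ccc(C(=O)O)cc1S(=O)(=O)N(C)C` gives 70.6% in this assay.

Going by the values given here, compound 2 holds the higher of the two numbers recorded in this assay, and its only neighbour is compound 1. Among the compounds with values here, the single measured step, a number 55 percentage points higher from compound 1 to compound 2 (beyond the scatter), is large and goes with lengthening of the chain on the aromatic nitrogen.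

Compound 3 `CN(C)S(=O)(=O)c1cc(C(=O)O)ccc1NCCCC(F)(F)F` is not yet measured. It differs from compound 2 by trifluoromethyl in place of pentyl on a saturated chain carbon, three bonds along the chain from a nitrogen on an aromatic ring. That change cuts the chain back to about the length found in compound 1, so the step of a number 55 percentage points higher from compound 1 to compound 2 (beyond the scatter) is the relevant guide, read in reverse. The expected step is therefore a number 40.6 percentage points lower from compound 2 to compound 3 (beyond the scatter), a decrease beyond the scatter, though the trifluoromethyl end leaves some uncertainty. Compound 3 is estimated at 30% in this assay, with a range from 10% to 55%.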

Compound 3, a percentage reported as inhibition, at one concentration (the size of the read-out at that concentration, not a potency): 1.9%
For compound 3 the middle estimate is 28.1 percentage points above the measured one, outside the stated range (below it).
By their numbers in this assay, from the lowest: compound 3; then compound 1; then compound 2.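

In this assay, the step of a number 68.7 percentage points lower from compound 2 to compound 3 (beyond the scatter) shows that this position tolerates the change from octyl to 4,4,4-trifluorobutyl poorly. The step of a number 13.7 percentage points lower from compound 1 to compound 3 (beyond the scatter) adds what the earlier pair could not show: at about the same chain length, the trifluoromethyl end gives a lower number than the plain methyl end of butyl, so chain length alone does not set the read-out at this position. Nothing shown here gives a reason for this difference.

The compounds shown leave open whether a trifluoromethyl end would also lower the number on a longer chain, such as an octyl chain ending in trifluoromethyl. They also leave open how the read-out moves through the chain lengths between butyl and octyl, such as hexyl, and on chains longer than octyl.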